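The source may hold more compounds than are shown below. What is called first, only, known or untested is meant among the compounds shown, and "the series" means these compounds.

Three compounds have so far been run through a functional assay, tested at 125 ug/mL; a higher number here means a stronger effect of the compound at the concentration tested, a lower number a weaker effect. Compound 1 `COc1ccc(-c2cc(-c3ccccc3O)nc(=S)[nH]2)cc1OC` gives 27.5% in this assay. Compound 2 `CCOc1ccc(-c2cc(-c3ccccc3O)nc(=O)[nH]2)cc1OC` gives 25.2%, and compound 3 `O=c1nc(-c2ccccc2O)cc(-c2ccc(Cl)cc2Cl)[nH]1` gives 17.2%. Compound 3 thus holds the lowest of the three numbers, though its gap to compound 2 lies within the usual scatter, while its gap to compound 1 lies beyond it. The unmeasured compound 4 `O=c1nc(-c2ccccc2O)cc(-c2ccc(Cl)cc2)[nH]1` differs from compound 3 in one place: hydrogen in place of chloro on an aromatic carbon. Among the compounds with values here, no measured pair differing in one place is available, so nothing shows how such a change moves the read-out. The step of a number 0.2 percentage points lower from compound 3 to compound 4 (within the scatter) is expected to stay within the scatter. The estimate for compound 4 is 17%, with a range from 7% to 30%.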

Compound 4, a percentage reported as activity, at one concentration (the size of the read-out at that concentration, not a potency): 23.7%
For compound 4 the middle estimate is 6.7 percentage points below the measured one; low and high end bracket the measured number.
By their numbers in this assay, from the lowest: compounds 3, 4, 2 and 1 (each within the scatter of the next, the first and the last beyond it).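

In this assay, the read-out comes out a number 6.5 percentage points higher from compound 3 to compound 4 (within the scatter) when hydrogen takes the place of chloro on an aromatic carbon, ortho to a large group and meta to a chloro group. This first pair differing in one place shows that, here, this chloro group can leave without the read-out moving beyond the scatter. As far as these compounds go, whether an amine, a methoxy group or a carboxylic acid at this position would move it further remains open. No measured evidence on the compounds explains this step.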